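Aryl variation on the ring amine nitrogen: notes on one series

This account rests on a few compounds, and the source may have more. Where it says the series, first, only, none or still open, it means among the compounds named here.

Measured so far in an assay on CHO cells for displacement of a labelled ligand from adenosine receptor A3 (Homo sapiens), read by scintillation counting, with a stated time of 120 min, tested at 10 uM; a higher number here means more inhibition at the concentration tested (going by the name of the read-out), a lower number less inhibition:
compound 1 `Nc1scc(CN2CCN(c3ccc(Cl)cc3Cl)CC2)c1C(=O)c1ccc(Cl)cc1` gives 0%
compound 2 `Nc1scc(CN2CCN(c3cccc(Cl)c3Cl)CC2)c1C(=O)c1ccc(Cl)cc1` gives 0%
compound 3 `COc1ccc(N2CCN(Cc3csc(N)c3C(=O)c3ccc(Cl)cc3)CC2)cc1` gives 0%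

Compound 1 stands level with compound 2 and compound 3 at the digits given; its nearest neighbour is compound 2 and its furthest is compound 3, and neither gap goes beyond the scatter. The three steps between them, each a swap of the aryl group on the amine nitrogen in the ring, read no change at the digits printed from compound 1 to compound 2 (within the scatter), no change at the digits printed from compound 1 to compound 3 (within the scatter) and no change at the digits printed from compound 2 to compound 3 (within the scatter). Two dichlorophenyl patterns and a 4-methoxyphenyl all give the same reading in this assay.

Compound 4 `Nc1scc(CN2CCN(c3cc(F)cc(F)c3)CC2)c1C(=O)c1ccc(Cl)cc1` is not yet measured. Relative to compound 1 the change is 3,5-difluorophenyl in place of 2,4-dichlorophenyl on an amine nitrogen in a ring. The steps from compound 1 to compound 2 and from compound 1 to compound 3 bear directly on this, since both vary the same aryl group at the same place, and both showed no change. The expected step in this assay is therefore none beyond the scatter, in either direction: no change at the digits printed from compound 1 to compound 4 (within the scatter). For compound 4 the estimated reading is 0%, with a range from -10% to 12%.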

Compound 4, a percentage reported as inhibition, at one concentration (the size of the read-out at that concentration, not a potency): 2%
Compound 4: the middle estimate sits 2 percentage points below what was measured, within the range that was stated.
By their numbers in this assay, from the lowest: compounds 1, 2, 3 and 4 (each within the scatter of the next).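

Notes on the aryl group on an amine nitrogen in a ring: in this assay the steps read a number 2 percentage points higher from compound 1 to compound 4 (within the scatter), a number 2 percentage points higher from compound 2 to compound 4 (within the scatter) and a number 2 percentage points higher from compound 3 to compound 4 (within the scatter). The earlier compounds shown here covered only dichlorophenyl and 4-methoxyphenyl groups, so the 3,5-difluorophenyl group of compound 4 adds fluorine and a further substitution pattern to the set, and the four aryl groups still cannot be told apart at the one concentration tested. The exchange of 2,4-dichlorophenyl for 3,5-difluorophenyl keeps the heavy-atom count, the carbon-only aromatic ring and the absence of charge, hydrogen-bond donors and hydrogen-bond acceptors, and no measurement shown explains the flat readings across this series.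

The compounds shown leave open whether a group of a different kind at this place, such as a benzyl group, a pyridyl ring or a phenyl ring carrying a carboxylic acid or a primary amine, would give a reading beyond the scatter. They also leave open whether replacing the 4-chlorophenyl ketone on the shared core, rather than this aryl group, would change the reading.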